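The source may hold more compounds than are shown below. What is called first, only, known or untested is meant among the compounds shown, and "the series" means these compounds.

Working notes on the series. Compound 1 `CN(C)CCn1c(N)c(-c2nc3ccccc3n2C)c2nc(C#N)c(C#N)nc21` carries dimethylamino on a saturated chain carbon, two bonds along the chain from an aromatic nitrogen. In a functional assay on cells (Homo sapiens) for antiproliferative activity, read by MTT assay, with a stated time of 48 h (a lower number here means a stronger inhibitor, a higher number a weaker inhibitor), compound 1 gives only a limit, > 50000 nM. Compound 2 `CCN(CC)CCn1c(N)c(-c2nc3ccccc3n2C)c2nc(C#N)c(C#N)nc21` differs from compound 1 by diethylamino in place of dimethylamino on a saturated chain carbon, two bonds along the chain from an aromatic nitrogen. In this assay compound 2 likewise gives only a limit, > 50000 nM. The step that the two limits leave unreadable from compound 1 to compound 2 is therefore not readable, because both values sit at the limit of > 50000 nM in this assay, at which 2 of the 3 values shown sit.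

Compound 3 `CN(C)CCCCn1c(N)c(-c2nc3cc(Cl)ccc3[nH]2)c2nc(C#N)c(C#N)nc21` rests on a different core; the difference between the core of compound 3 and the core of compound 1 is not broken down here. In this assay, among the measured compounds shown here, compound 3 gives 3280 nM, the only number among the three measured compounds. Compound 4 `CCN(CC)CCCCn1c(N)c(-c2nc3cc(Cl)ccc3[nH]2)c2nc(C#N)c(C#N)nc21` differs from compound 3 by diethylamino in place of dimethylamino on a saturated chain carbon, four bonds along the chain from an aromatic nitrogen. This is the same kind of change as from compound 1 to compound 2, but the place differs: there the group sits two bonds along the chain from an aromatic nitrogen, here four bonds along the chain from an aromatic nitrogen. For the measured compounds named here, the step of a 1.1-fold higher number from compound 3 to compound 4 (0.03 log units; within the scatter) is estimated to stay within the usual scatter, since the one precedent a step that the two limits leave unreadable from compound 1 to compound 2 gives no size. In this assay compound 4 is expected to give 3500 nM, with a range from 1200 nM to 11000 nM.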

Compound 4, half-maximal inhibitory concentration: 2840 nM
Beside the measured number, compound 4's estimate is 1.2-fold (0.09 log units) above it, and the stated range covers the measured number.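

In this assay, diethylamino in place of dimethylamino, on a saturated chain carbon four bonds along the chain from an aromatic nitrogen, comes with a 1.2-fold lower number from compound 3 to compound 4 (0.06 log units; within the scatter), so on this core the change leaves the number within the scatter. Compound 1 and compound 2 each give only a limit, so the same kind of change on the other core cannot be read: the limit of > 50000 nM in this assay, at which 2 of the 4 values shown sit. With one readable step, and with the group sitting at a different place along the chain in the two pairs, the series shows neither that the change carries from one core to the other nor that it fails to do so.

Open, from the compounds shown here alone, is how the change reads on the core of compound 1 in a range where its compounds give numbers rather than limits. Also open, going by these compounds, is how a primary amine or a carboxylic acid at the chain end, or a longer chain, would read on either core.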